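This account rests on a few compounds, and the source may have more. Where it says the series, first, only, none or still open, it means among the compounds named here.

Measured so far in a functional assay on PC-3 cells (Homo sapiens) for antiproliferative activity, read by MTT assay, with a stated time of 48 h; a lower number here means a stronger inhibitor, a higher number a weaker inhibitor:
Compound 1 `Cc1ccc(-c2csc(N3C(=O)c4ccccc4C3=O)n2)cc1` gives 38400 nM.
Compound 2 `O=C1c2ccc(F)cc2C(=O)N1c1nc(-c2ccc(F)cc2)cs1` gives 39500 nM.
Compound 3 `O=C1c2ccc(F)cc2C(=O)N1c1nc(-c2ccc(Cl)cc2)cs1` gives 38000 nM.

Compound 3 sits within the usual scatter of both compound 1 and compound 2 in this assay; the three numbers cannot be told apart. Going by the values given here, the only measured step between neighbours is a 1.0-fold lower number from compound 2 to compound 3 (0.02 log units; within the scatter). Compound 4 `Cc1ccc(-c2csc(N3C(=O)c4ccc(F)cc4C3=O)n2)cc1` differs from compound 3 by methyl in place of chloro on an aromatic carbon. Compound 1 also carries a 4-methylphenyl group but lacks the fluoro on the shared core, and its number matches that of compound 3. Among the compounds with values here, with no step in this small set reaching beyond the scatter, the change is expected to leave this assay essentially unchanged, that is no change at the digits printed from compound 3 to compound 4 (within the scatter). Compound 4 is therefore estimated at 38000 nM, with a likely range from 20000 nM to 75000 nM.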

Compound 4, half-maximal inhibitory concentration: 44400 nM
Beside the measured number, compound 4's estimate is 1.2-fold (0.07 log units) below it, within the range that was stated.
By their numbers in this assay, from the lowest: compounds 3, 1, 2 and 4 (each within the scatter of the next).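

In this assay, swapping 4-chlorophenyl for 4-methylphenyl gives a 1.2-fold higher number from compound 3 to compound 4 (0.07 log units; within the scatter) and so stays level. Methyl in place of fluoro at that same position gives a 1.1-fold higher number from compound 2 to compound 4 (0.05 log units; within the scatter) and makes this the third group there with no readable shift, while adding fluoro to the shared core with the methyl group present gives a 1.2-fold higher number from compound 1 to compound 4 (0.06 log units; within the scatter) and is equally flat.

Going by these compounds, whether an amine or a carboxylic acid at this position would move the number beyond the scatter stays open. No supporting data explain why these four numbers stay level.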